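From Ethyl Amide to Sulfonyl Amide: Estimating Rat Clearance

This account rests on a few compounds, and the source may have more. Where it says the series, first, only, none or still open, it means among the compounds named here.

In an in vivo ADME assay on the whole organism (plasma) for pharmacokinetics, with Rattus norvegicus as the target, at a dose of 5 mg/kg by the intravenous route (a higher number here means faster removal of the compound, a lower number slower removal), compound 1 (`CCNC(=O)c1ccccc1CCC(SCC(CC)C(=O)O)c1cccc(OCc2ccc3ccc(Cl)cc3n2)c1`) gives 106 mL/min/kg. Compound 2 (`O=C(O)CCSC(CCc1ccccc1-c1nc[nH]n1)c1cccc(OCc2ccc3ccc(Cl)cc3n2)c1`) gives 64 mL/min/kg, which lies within the usual scatter of compound 1, so these two sit together at the high end of the three numbers. Compound 3 (`CCC(CSC(CCc1ccccc1C(=O)O)c1cccc(OCc2ccc3ccc(Cl)cc3n2)c1)C(=O)O`) is far from both, at 8.8 mL/min/kg.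

Compound 4 (`CCC(CSC(CCc1ccccc1C(=O)NS(=O)(=O)c1ccccc1C)c1cccc(OCc2ccc3ccc(Cl)cc3n2)c1)C(=O)O`) has not yet been measured. It keeps the core of compound 1 and changes one group: (2-methylphenyl)sulfonyl in place of ethyl on an amide-type nitrogen.

Going by the values given here, only one measured step touches this part of the molecule. Putting hydroxy in place of ethylamino on a carbonyl carbon gave a 12-fold lower number from compound 1 to compound 3 (1.08 log units; beyond the scatter), a large step beyond the scatter. Compound 2 differs from compound 1 in more than one place, so it offers no clean comparison. Among the compounds with values here, no measured compound carries the new sulfonyl group, which leaves the size of the change uncertain.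

The single large drop seen with compound 3 at 8.8 mL/min/kg points to a lower number here too, though probably a smaller drop. The expected change is a 5.3-fold lower number from compound 1 to compound 4 (0.72 log units; beyond the scatter). For compound 4 the estimate is 20 mL/min/kg, with an expected range of 7 mL/min/kg to 55 mL/min/kg.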

Compound 4, clearance: 15 mL/min/kg
For compound 4 the middle estimate is 1.3-fold (0.12 log units) above the measured one, within the range that was stated.
By their numbers in this assay, from the lowest: compounds 3 and 4 (each within the scatter of the next); then compounds 2 and 1 (each within the scatter of the next).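

In this assay, (2-methylphenyl)sulfonyl in place of ethyl on an amide-type nitrogen gives a 7.1-fold lower number from compound 1 to compound 4 (0.85 log units; beyond the scatter). The earlier drop came with the whole ethylamino group replaced by hydroxy, whereas this one shows that the number can also fall with the amide-type nitrogen kept and only its ethyl replaced. Setting ((2-methylphenyl)sulfonyl)amino in place of hydroxy on a carbonyl carbon gives a 1.7-fold higher number from compound 3 to compound 4 (0.23 log units; within the scatter), so this read-out does not separate these two quite different groups, and a carboxylic acid at that carbonyl is not the only way to reach the low end of the series; no measurement here explains why either change lowers the number.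

The entering group brings a sulfonyl, a six-membered aromatic ring and a methyl together, so the compounds shown cannot say which of these parts goes with the step. A methylsulfonyl group, which has no ring, or an unsubstituted phenylsulfonyl group on the same nitrogen would begin to pull these parts apart, and a longer alkyl chain there would show whether simply replacing ethyl matters.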